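A few compounds are considered here, and "the series" means these few. Any claim that something is new, unique, unknown or untested is made for them only; others in the source may bear on it.

Working notes on the series. The shared core is carried by compound 1 `Fc1ccc(-n2cc(COc3ccccc3-c3nc4ccccc4s3)nn2)cc1` and by compound 2 `FC(F)(F)C(F)(F)C(F)(F)C(F)(F)C(F)(F)C(F)(F)C(F)(F)C(F)(F)CCn1cc(COc2ccccc2-c2nc3ccccc3s2)nn1`. In a functional assay on A549 cells (Homo sapiens) for cytotoxicity, read by MTT assay, with a stated time of 24 h (a higher number here means a weaker inhibitor, a lower number a stronger inhibitor), compound 1 gives 23300 nM, the highest of the two numbers recorded so far; the nearest is compound 2, which in this assay gives 13100 nM, a gap that lies within the usual scatter. Compound 3 `c1ccc(-n2cc(COc3ccccc3-c3nc4ccccc4s3)nn2)cc1` has not yet been measured. It differs from compound 1 in one place: hydrogen in place of fluoro on an aromatic carbon. Among the compounds with values here, no step between two measured compounds in this assay is available to set the size of such a change, so the expectation rests on compound 1 alone, with compound 2 as the only other point. Loss of the fluoro is expected to move the number little: the expected step of a 1.1-fold higher number from compound 1 to compound 3 (0.03 log units; within the scatter) is none beyond the scatter, in either direction. Compound 3 is therefore expected to give about 25000 nM in this assay, with a range from 10000 nM to 60000 nM.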

Compound 3, half-maximal inhibitory concentration: 16400 nM
Compound 3: middle estimate off by 1.5-fold (0.18 log units), on the high side; the range from low to high includes it.
By their numbers in this assay, from the lowest: compounds 2, 3 and 1 (each within the scatter of the next).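

In this assay the change from 4-fluorophenyl to phenyl gives a 1.4-fold lower number from compound 1 to compound 3 (0.15 log units; within the scatter) as the first step read at this position. Taking the fluoro off this aromatic carbon, para to a large group, therefore produces no change that can be told from the scatter, and compound 3 shows that the fluoro is not required for a number in this range. No measurement given here bears on the reason for this result.

Only hydrogen and fluoro have been compared at this position, so an amine, a carboxylic acid or a methoxy group on the same carbon could either leave the number where it is or move it beyond the scatter. A shorter alkyl chain in place of the phenyl also remains unread.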